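The compounds below may be only part of what the source reports. "The series", "measured", "known", "first", "only" and "open" are said of these compounds alone.

Compound 1 `OC1CNCCC1N1CCN(c2ccccc2)CC1` was tested in an assay on PC-12 cells for displacement of a labelled ligand from vesicular acetylcholine transporter (Homo sapiens) (on this read-out lower numbers stand for stronger inhibition and higher numbers for weaker inhibition), where compound 1 gives 100 nM. Compound 2 `OC1CN(Cc2ccccc2)CCC1N1CCN(c2ccccc2)CC1` carries benzyl in place of hydrogen on an amine nitrogen in a ring; in this assay compound 2 gives 57 nM, a change of a 1.8-fold lower number from compound 1 to compound 2 (0.24 log units; within the scatter). Compound 3 `OC1CCNCC1N1CCN(c2ccccc2)CC1` has the same atoms as compound 1 joined differently; how the two cores differ is not broken down here. For compound 3 this assay reports only a limit, > 100 nM, which is the limit of > 100 nM in this assay, at which 1 of the 3 values shown sits. Compound 4 `OC1CCN(Cc2ccccc2)CC1N1CCN(c2ccccc2)CC1` arises from compound 3 by the same kind of change, (benzyl in place of hydrogen on an amine nitrogen in a ring); here the place is two ring bonds from the ring atom that bears a large group and three ring bonds from the ring atom that bears a hydroxy group. Resting on the step of a 1.8-fold lower number from compound 1 to compound 2 (0.24 log units; within the scatter), an expected step that the limit leaves unreadable from compound 3 to compound 4 follows. Compound 4 is estimated at 150 nM, between 40 nM and 600 nM.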

Compound 4, half-maximal inhibitory concentration: > 100 nM
Compound 4 gave a limit, no number; the forecaster's own chance of this, stated with the estimate: 40%; the middle value is on the limit's open side.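

Compound 3 and compound 4 each give only a limit, not a number, so no step between them can be read: the limit of > 100 nM in this assay, at which 2 of the 4 values shown sit.

The compounds shown leave open how far benzyl in place of hydrogen on the ring nitrogen shifts the result on the core of compound 3 in this assay.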